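Replacing the group on the carbonyl carbon of compound 3

This account rests on a few compounds, and the source may have more. Where it says the series, first, only, none or still open, it means among the compounds named here.

- compound 1 `Cc1ccc2[nH]c(C(=O)N[C@H]3CN(S(=O)(=O)c4ccccc4)C[C@@H]3C(=O)NC[C@H]3CCCN3)cc2c1` gives 0.11 10^-6 cm/s
- compound 2 `Cc1ccc2[nH]c(C(=O)N[C@H]3CN(S(=O)(=O)c4ccccc4)C[C@@H]3C(=O)NC[C@@H]3CCCN3C)cc2c1` gives 0.24 10^-6 cm/s
- compound 3 `Cc1csc(C(=O)N[C@H]2CN(S(=O)(=O)c3ccccc3)C[C@@H]2C(=O)N[C@H]2CCCNC2)n1` gives 0.18 10^-6 cm/s

In an ADME assay on Caco-2 cells (Homo sapiens) for permeability, in the apical to basolateral direction, at pH 7.4 (a lower number here means that the compound crosses the layer more slowly, a higher number that the compound crosses the layer faster), compound 3 gives 0.18 10^-6 cm/s and so lies within the usual scatter of both compound 1 and compound 2. Compound 4 `O=C(N[C@H]1CN(S(=O)(=O)c2ccccc2)C[C@@H]1C(=O)N[C@H]1CCCNC1)c1cc(C2CC2)n[nH]1` has not been measured yet. It carries 3-cyclopropyl-1H-pyrazol-5-yl in place of 4-methyl-1,3-thiazol-2-yl on a carbonyl carbon. Within the data shown here, the one measured step (a 2.2-fold higher number from compound 1 to compound 2 (0.34 log units; beyond the scatter)) puts 1-methylpyrrolidin-2-yl in place of pyrrolidin-2-yl on a saturated chain carbon. That is a different place, so it bears only loosely on this change, as a hint of how large a single change can be in this small set. Among the measured compounds shown here, no measured step exists for a change on the carbonyl carbon. In this assay the expected step is small (a 1.2-fold lower number from compound 3 to compound 4 (0.08 log units; within the scatter)) and stays within the scatter. Compound 4 is estimated at 0.15 10^-6 cm/s with an expected range from 0.06 10^-6 cm/s to 0.4 10^-6 cm/s as the likely span.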

Compound 4, apparent permeability: 0.39 10^-6 cm/s
For compound 4 the middle estimate is 2.6-fold (0.41 log units) below the measured one, and the stated range covers the measured number.
By their numbers in this assay, from the lowest: compounds 1, 3, 2 and 4 (each within the scatter of the next, the first and the last beyond it).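

In this assay, the change on the carbonyl carbon gives a 2.2-fold higher number from compound 3 to compound 4 (0.34 log units; beyond the scatter), so this place can move the number beyond the scatter, just as the change on the saturated chain carbon does with a 2.2-fold higher number from compound 1 to compound 2 (0.34 log units; beyond the scatter). The entering 3-cyclopropyl-1H-pyrazol-5-yl differs from 4-methyl-1,3-thiazol-2-yl in several ways at once, with a three-membered carbon ring, no sulfur and a hydrogen-bond donor, so this single step cannot show which difference goes with the higher number. No available evidence bears on this step.

A pyrazole carrying a methyl group in place of cyclopropyl, or a plain phenyl ring, would help separate these differences. As far as these compounds go, it also remains open whether 3-cyclopropyl-1H-pyrazol-5-yl gives a similar step when the amide carries the pyrrolidin-2-yl group of compound 1.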